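Pyridine substituent swap in a TRPV1 antagonist pair

The compounds below may be only part of what the source reports. "The series", "measured", "known", "first", "only" and "open" are said of these compounds alone.

Compound 1 `C[C@@H]1CN(c2ncccc2C(F)(F)F)CCN1C(=O)Nc1ccc(C(F)(F)F)cc1`: 11 nM
Compound 2 `CCCOc1cccnc1-c1ccc(C(=O)Nc2ccc(C(C)(C)C)cc2)cc1`: 20 nM

Of the compounds shown here, two have been measured in a functional assay for antagonist activity at transient receptor potential cation channel subfamily V member 1 (Rattus norvegicus); a higher number here means a weaker inhibitor, a lower number a stronger inhibitor. Compound 1 gives 11 nM and compound 2 gives 20 nM; the gap between them is within the usual scatter, so neither stands apart from the other. Compound 3 `CC(C)(C)c1ccc(NC(=O)c2ccc(-c3ncccc3NS(C)(=O)=O)cc2)cc1` carries methanesulfonamido in place of propoxy on an aromatic carbon. Among the compounds with values here, no measured pair isolates this change, so any expectation rests on the structural change alone. Compound 3 is expected to lose some potency in this assay, an estimated step of a 3.0-fold higher number from compound 2 to compound 3 (0.48 log units; beyond the scatter), modest but beyond the scatter. Compound 3 is estimated at 60 nM, with a range of 12 nM to 400 nM.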

Compound 3, half-maximal inhibitory concentration: 35 nM
Compound 3: middle estimate off by 1.7-fold (0.23 log units), on the high side; the measured number falls inside the stated range.
By their numbers in this assay, from the lowest: compounds 1, 2 and 3 (each within the scatter of the next, the first and the last beyond it).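

In this assay, methanesulfonamido in place of propoxy on this aromatic carbon, ortho to a large group and two atoms from the ring nitrogen, gives a 1.8-fold higher number from compound 2 to compound 3 (0.24 log units; within the scatter). This position therefore accepts either group without a step beyond the scatter, even though the entering group carries a hydrogen-bond donor that propoxy lacks. No supporting data explain this tolerance. 

Still open, going by these compounds, is whether an amine, a carboxylic acid or a longer alkoxy chain on this carbon would stay within the scatter of these two compounds.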